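The compounds below may be only part of what the source reports. "The series", "measured", "known", "first", "only" and "open" are said of these compounds alone.

Measured in a functional assay on OVCAR-3 cells (Homo sapiens) for antiproliferative activity, read by MTT assay, with a stated time of 24 h; a higher number here means a weaker inhibitor, a lower number a stronger inhibitor:
- compound 1, `O=c1[nH]cc(S(=O)(=O)Nc2ccc(-c3cn(-c4ccccc4)nn3)cc2)c(=O)[nH]1`: 18000 nM
- compound 2, `Cc1ccccc1-n1cc(-c2ccc(NS(=O)(=O)c3c[nH]c(=O)[nH]c3=O)cc2)nn1`: 7310 nM
- compound 3, `Cc1ccc(-n2cc(-c3ccc(NS(=O)(=O)c4c[nH]c(=O)[nH]c4=O)cc3)nn2)cc1`: 5630 nM

Compound 3 gives the lowest number of the three, but its gap to compound 2 is within the scatter, a 1.3-fold lower number from compound 2 to compound 3 (0.11 log units; within the scatter); only against compound 1 does it stand clearly apart, a 3.2-fold lower number from compound 1 to compound 3 (0.50 log units; beyond the scatter). So the series supports one reading only: a methyl on the phenyl attached to the ring nitrogen lowers the number modestly, whichever of the two positions carries it, a 2.5-fold lower number from compound 1 to compound 2 (0.39 log units; beyond the scatter).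

Compound 4, `O=c1[nH]cc(S(=O)(=O)Nc2ccc(-c3cn(-c4ccccc4F)nn3)cc2)c(=O)[nH]1`, replaces that phenyl again: 2-fluorophenyl in place of 4-methylphenyl on an aromatic nitrogen. The methyl is gone, which on the evidence of compound 1 pulls back toward the higher number; the fluorine is new to the series and nothing measured bears on it. The steps that apply are those from compound 1 to compounds 2 and 3, both modest, so a modest rise from compound 3 to compound 4 in this assay is expected, smaller than a full return to compound 1, a 1.7-fold higher number from compound 3 to compound 4 (0.23 log units; within the scatter). Compound 4 is therefore estimated at 9500 nM, within 3500 nM to 25000 nM.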

Compound 4, half-maximal inhibitory concentration: 8030 nM
Compound 4: middle estimate off by 1.2-fold (0.07 log units), on the high side; the range from low to high includes it.
By their numbers in this assay, from the lowest: compounds 3, 2 and 4 (each within the scatter of the next); then compound 1.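

In this assay the 2-fluorophenyl on the aromatic nitrogen cannot be told apart from either methyl-bearing phenyl (a 1.4-fold higher number from compound 3 to compound 4 (0.15 log units; within the scatter)) and (a 1.1-fold higher number from compound 2 to compound 4 (0.04 log units; within the scatter)), so fluoro in place of methyl on this aromatic carbon leaves no readable change. Set against the phenyl without a substituent, the 2-fluorophenyl still gives a modest drop (a 2.2-fold lower number from compound 1 to compound 4 (0.35 log units; beyond the scatter)), so among these compounds the lower number is no longer tied to methyl: compound 2, compound 3 and compound 4 all lie clearly below compound 1, and none goes against this. Nothing available here accounts for this result.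

As far as these compounds go, whether the drop would persist with an amine, a carboxylic acid or a longer alkyl chain on this phenyl remains open. Whether any change to this phenyl can go beyond a modest step is also unanswered.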